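The source may report more compounds than this note shows. Statements on the series, on what has been measured and on what is new or still open speak of the compounds shown alone.

Measured so far in an in vitro ADME assay on microsomes from liver (Mus musculus) for pharmacokinetics, read by LC-MS, with a stated time of 10 min, tested at 1 uM; a higher number here means faster removal of the compound, a lower number slower removal:
- compound 1 `CN1C[C@H](C(=O)Nc2cccc(Cl)c2)[C@@H](c2ccc(/C=C/C(=O)Nc3ccccc3N)cc2)C1` gives 58 mL/min/kg
- compound 2 `CN1C[C@H](C(=O)Nc2ccccc2F)[C@@H](c2ccc(/C=C/C(=O)Nc3ccccc3N)cc2)C1` gives 67 mL/min/kg
- compound 3 `CN1C[C@H](C(=O)Nc2ccc(Cl)c(Cl)c2)[C@@H](c2ccc(/C=C/C(=O)Nc3ccccc3N)cc2)C1` gives 36 mL/min/kg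

Compound 3 cannot be told apart from the other two: a 1.6-fold lower number from compound 1 to compound 3 (0.21 log units; within the scatter) and a 1.9-fold lower number from compound 2 to compound 3 (0.27 log units; within the scatter) are both small. Compound 4 `CN1C[C@H](C(=O)Nc2ccc(Cl)cc2F)[C@@H](c2ccc(/C=C/C(=O)Nc3ccccc3N)cc2)C1` differs from compound 3 as follows: 4-chloro-2-fluorophenyl in place of 3,4-dichlorophenyl on an amide-type nitrogen. In short, 4-chloro-2-fluorophenyl stands in place of 3,4-dichlorophenyl on an amide-type nitrogen. Compound 2 also carries a 2-fluorophenyl group, so a 1.9-fold lower number from compound 2 to compound 3 (0.27 log units; within the scatter) bears most directly, and a 1.2-fold higher number from compound 1 to compound 2 (0.06 log units; within the scatter) is also small. No step beyond the scatter is therefore expected in this assay, only perhaps a slight drift toward the number of compound 2. The estimate means a 1.4-fold higher number from compound 3 to compound 4 (0.14 log units; within the scatter) as the expected step. For compound 4 the estimated clearance is 50 mL/min/kg (expected range 30 mL/min/kg to 80 mL/min/kg).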

Compound 4, clearance: 43 mL/min/kg
Compound 4: the middle estimate sits 1.2-fold (0.07 log units) above what was measured; the measured number falls inside the stated range.
By their numbers in this assay, from the lowest: compounds 3, 4, 1 and 2 (each within the scatter of the next).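

In this assay, 4-chloro-2-fluorophenyl on the amide-type nitrogen cannot be told apart from 3,4-dichlorophenyl, a 1.2-fold higher number from compound 3 to compound 4 (0.08 log units; within the scatter), or from 3-chlorophenyl, a 1.3-fold lower number from compound 1 to compound 4 (0.13 log units; within the scatter). Chloro in place of hydrogen on an aromatic carbon, a 1.6-fold lower number from compound 2 to compound 4 (0.19 log units; within the scatter), stays within the scatter too. That same change now appears twice and gives closely matching steps: the same change on two cores in this assay, a 1.6-fold lower number (0.21 log units; within the scatter) from compound 1 to compound 3 and a 1.6-fold lower number (0.19 log units; within the scatter) from compound 2 to compound 4, 1.0-fold (0.01 log units) apart, within the scatter of two such steps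

Every group shown at this position is a phenyl ring carrying halogens. From the compounds shown here alone, whether an amine or a carboxylic acid on that ring would shift clearance beyond the scatter remains open.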